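Methyl on the aromatic oxygen: two matched pairs

The compounds below may be only part of what the source reports. "The series", "measured", "known", "first", "only" and "open" are said of these compounds alone.

Measured compounds:
compound 1 `O=C(Nc1ccccc1)c1cc(Br)ccc1O` — > 100000 nM in an assay on isolated protein for inhibition of thiosulfate sulfurtransferase (Homo sapiens), with a stated time of 60 min, in the absence of a further agent (on this read-out higher numbers stand for weaker inhibition and lower numbers for stronger inhibition), a limit of the assay
compound 2 `COc1ccc(Br)cc1C(=O)Nc1ccccc1` — > 100000 nM in this assay, a limit
compound 3 `O=C(Nc1cccc(Cl)c1)c1cccc(Br)c1O` — > 100000 nM in this assay, a limit

Compound 1 in this assay gives only a limit of the assay, not a number. Compound 2 likewise gives only a limit. Compound 3 also sits at a limit. The change methyl in place of hydrogen on an oxygen on an aromatic ring gives the step that the two limits leave unreadable from compound 1 to compound 2; because the limit of > 100000 nM in this assay, at which 3 of the 3 values shown sit, nothing can be read from it. The difference between the cores of compound 1 and compound 3 is not broken down here. Compound 4 `COc1c(Br)cccc1C(=O)Nc1cccc(Cl)c1` carries the same change, (methyl in place of hydrogen on an oxygen on an aromatic ring), on the core of compound 3. For compound 4 the expected step is a number no higher from compound 3 to compound 4 (the limit leaves the size open), resting on compound 1 and compound 2 both sitting at the limit of > 100000 nM in this assay, at which 3 of the 3 values shown sit. Compound 4 is therefore estimated at 100000 nM, most likely again only a limit, between 30000 nM and 300000 nM.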

Compound 4, half-maximal inhibitory concentration: > 100000 nM
Compound 4: a limit, no number; the forecaster's own chance of this, stated with the estimate: 85%; the middle value sits exactly at the limit.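

No step can be read from compound 3 to compound 4, since neither compound gives a number: the limit of > 100000 nM in this assay, at which 4 of the 4 values shown sit.

The compounds shown leave open whether hydroxy to methoxy changes inhibition at all on either core.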